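The source may hold more compounds than are shown below. What is called first, only, known or untested is meant among the compounds shown, and "the series" means these compounds.

In a functional assay on PC-3 cells (Homo sapiens) for antiproliferative activity, read by MTT assay, with a stated time of 72 h (on this read-out lower numbers stand for stronger inhibition and higher numbers for weaker inhibition), compound 1 (`CCN(CC)CCn1cccc1/C=N/NC(=O)Nc1ccc(Oc2ccnc3[nH]ccc23)cc1`) gives 1370 nM, while compound 2 (`O=C(N/N=C/c1cccn1CCCN1CCCCC1)Nc1ccc(Oc2ccnc3[nH]ccc23)c(F)c1`) gives 2840 nM. Compound 2 thus holds the higher of the two numbers and the weaker result, with a gap beyond the usual scatter. Compound 3 (`O=C(N/N=C/c1cccn1CCCN1CCCCC1)Nc1ccc(Oc2ccnc3[nH]ccc23)cc1`) has not yet been measured. It differs from compound 2 by a single change, hydrogen in place of fluoro on an aromatic carbon. Among the compounds with values here, no measured pair shows this change alone, so the data offer no direct guide to its size. In this assay only a small step toward lower numbers is expected, probably not beyond the scatter, with compound 1 at 1370 nM as the sole other reference. The expected change is a 1.4-fold lower number from compound 2 to compound 3 (0.15 log units; within the scatter). For compound 3 the estimated value is 2000 nM, with an expected range of 800 nM to 5000 nM.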

Compound 3, half-maximal inhibitory concentration: 3580 nM
Compound 3: middle estimate off by 1.8-fold (0.25 log units), on the low side; the measured number falls inside the stated range.
By their numbers in this assay, from the lowest: compound 1; then compounds 2 and 3 (each within the scatter of the next).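

In this assay, hydrogen in place of fluoro on an aromatic carbon, ortho to a large group and meta to a large group, gives a 1.3-fold higher number from compound 2 to compound 3 (0.10 log units; within the scatter), so this single change does not separate the two compounds at this position. The change at the other end of the molecule, (piperidin-1-yl)methyl in place of diethylamino on a saturated chain carbon, two bonds along the chain from an aromatic nitrogen, gives a 2.6-fold higher number from compound 1 to compound 3 (0.42 log units; beyond the scatter), a modest step that does separate them. Nothing measured here accounts for either step.

Going by these compounds, it remains open whether a chloro or methoxy group on the same aromatic carbon would give a step beyond the scatter. On these data alone, it also remains open how a morpholin-4-yl or pyrrolidin-1-yl group at the end of the chain would compare with diethylamino.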